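Sulfonyl esters on the shared core: tolerance on HEp-2 cells

The source may report more compounds than this note shows. Statements on the series, on what has been measured and on what is new or still open speak of the compounds shown alone.

Three compounds of the series have numbers in an ADME assay on HEp-2 cells (Homo sapiens) for cytotoxicity, read by MTT assay, with a stated time of 60 h; a higher number here means that more compound is tolerated, a lower number that less compound is tolerated. Compound 1 `Cc1ccc(S(=O)(=O)O[C@@H]2CO[C@H]3[C@@H]2OCc2nc4cc(Br)c(C)c(Br)c4n23)cc1` gives 88600 nM. Compound 2 `Cc1c(Br)cc2nc3n(c2c1Br)[C@H]1OC[C@@H](O)[C@H]1OC3` gives 250000 nM. Compound 3 `COc1c(Cl)cc2c(nc3n2[C@H]2OC[C@@H](O)[C@H]2OC3)c1Cl` gives 411000 nM. One pair differs in a single place: a 2.8-fold higher number from compound 1 to compound 2 (0.45 log units; beyond the scatter). Compound 2 therefore stands second highest of the three; its nearest neighbour is compound 3, whose number sits within the scatter of that of compound 2, while the number of compound 1 lies beyond the scatter below it. Within the data shown here, no step links compound 3 to the others, so its value stands on its own.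

Compound 4 `Cc1c(Br)cc2nc3n(c2c1Br)[C@H]1OC[C@@H](OS(C)(=O)=O)[C@H]1OC3` has not yet been measured in this assay. It differs from compound 2 as follows: methylsulfonyl in place of hydrogen on an oxygen on a saturated carbon. Among the measured compounds shown here, the only step that bears on this change is the one from compound 1 to compound 2, in which the hydrogen replaces a (4-methylphenyl)sulfonyl on the same oxygen; compound 4 reverses that direction with a methylsulfonyl instead. A step downward is therefore expected, somewhat smaller than the tosyl step because a 2.8-fold higher number from compound 1 to compound 2 (0.45 log units; beyond the scatter) was itself modest. Compound 4 is estimated at 130000 nM, within 60000 nM to 280000 nM, which means an expected step of a 1.9-fold lower number from compound 2 to compound 4 (0.28 log units; within the scatter).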

Compound 4, half-maximal cytotoxic concentration: 23700 nM
Compound 4: middle estimate off by 5.5-fold (0.74 log units), on the high side; measured number below the stated range.
By their numbers in this assay, from the lowest: compound 4; then compound 1; then compounds 2 and 3 (each within the scatter of the next).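

Notes on the oxygen on a saturated carbon: in this assay, hydroxy to (methylsulfonyl)oxy gives a step much larger than the earlier comparison suggested, with an 11-fold lower number from compound 2 to compound 4 (1.02 log units; beyond the scatter) set against a 2.8-fold higher number from compound 1 to compound 2 (0.45 log units; beyond the scatter) for the (4-methylphenyl)sulfonyl pair. The group on the sulfonyl sulfur therefore matters as well as the presence of a sulfonyl at this oxygen, since methyl in place of 4-methylphenyl gives a 3.7-fold lower number from compound 1 to compound 4 (0.57 log units; beyond the scatter) in the same assay, and both sulfonyl compounds lie beyond the scatter below the free hydroxy of compound 2. The data shown contain no measurement that accounts for the size or direction of these steps.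

Still open, on these data alone, is whether the low number of compound 4 is specific to sulfonyl groups at this oxygen or would also appear with an acetyl ester, a methyl ether or an amine in place of the hydroxy, and whether an ethyl or longer chain on the sulfur would fall nearer to methyl or to 4-methylphenyl. Also open, as far as these compounds go, is whether methylsulfonyl on the hydroxy of compound 3, with its different substituents on the shared core, would give a step of similar size.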